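Plasma stability of the series: carboxyphenyl variation on the shared core

A few compounds are considered here, and "the series" means these few. Any claim that something is new, unique, unknown or untested is made for them only; others in the source may bear on it.

Of the compounds shown here, three have been measured so far in an ADME assay on a cell-free system (plasma, Rattus norvegicus) for metabolic stability, read by LC-MS, with a stated time of 1 h, at 37 degrees C, tested at 100 uM; on this read-out lower numbers stand for a less stable compound and higher numbers for a more stable compound. Compound 1 `O=C(O)c1cc(-c2cccc(COc3ccc4c(=O)n(C5CCC5)sc4c3)c2)ccc1Cl` gives 91%. Compound 2 `O=C(O)c1ccc(-c2cccc(COc3ccc4c(c3)CN(C3CCCC3)C4=O)c2)c(Cl)c1` gives 100% in this assay, and compound 3 `O=C(O)c1cc(-c2cccc(COc3ccc4c(=O)n(C5CCCC5)sc4c3)c2)ccc1F` gives 100%. Compound 2 stands level with compound 3 at the digits recorded, the two together the highest of the three numbers; the number for compound 1 differs from them, but that gap lies within the usual scatter of this assay, so no order among the three can be read from the data. All three measured compounds remain largely intact over the incubation.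

The next compound in the series is compound 4 `O=C(O)c1cc(F)cc(-c2cccc(COc3ccc4c(c3)CN(C3CCCC3)C4=O)c2)c1`, which is not yet measured. Relative to compound 2 the change is 3-carboxy-5-fluorophenyl in place of 4-carboxy-2-chlorophenyl on an aromatic carbon. For the measured compounds named here, no step between measured compounds differing in a single place is available, so the effect of this change has to be judged from the general level of the series alone.

Because compound 2 gives 100% and every measured compound sits near the top of the read-out, the step expected from compound 2 to compound 4, a number 4 percentage points lower from compound 2 to compound 4 (within the scatter), is none beyond the scatter. For compound 4 the estimate in this assay is 96%, with an expected range from 85% to 100%.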

Compound 4, percent of the compound remaining: 95%
Compound 4: middle estimate off by 1 percentage points, on the high side, within the range that was stated.
By their numbers in this assay, from the lowest: compounds 1, 4, 2 and 3 (each within the scatter of the next).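

In this assay the series now has its first step between compounds that differ in one place: 3-carboxy-5-fluorophenyl in place of 4-carboxy-2-chlorophenyl on an aromatic carbon gives a number 5 percentage points lower from compound 2 to compound 4 (within the scatter) and leaves compound 4 at 95%. Across this exchange of one substituted phenyl for another, which also changes chlorine to fluorine, the read-out shows no change that can be separated from the scatter, so this position tolerates at least this one replacement on the core of compound 2. No measured information accounts for this result.

For the compounds shown here, the single step joins the change of halogen with the different placement of the carboxyl group, so the contribution of each remains unresolved. From the compounds shown here alone, it also remains open whether the level holds when the carboxylic acid on this phenyl ring gives way to a methyl ester, a primary amide or a tetrazole, or when the ring carries a methoxy group in place of the halogen.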